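Ortho-substituted benzylamides: fluoro to trifluoromethyl step

The source may hold more compounds than are shown below. What is called first, only, known or untested is meant among the compounds shown, and "the series" means these compounds.

Compound 1 `CCC(C(=O)NCc1ccccc1)N1C(=O)CCC1=O` in a functional assay on the whole organism (strain Albino Swiss CD1) with Mus musculus as the target, in the maximal electroshock model (a lower number here means that less compound is needed, a higher number that more compound is needed for the effect), gives 73.3 mg/kg. Compound 2 `CCC(C(=O)NCc1ccccc1Cl)N1C(=O)CCC1=O` in this assay gives 113 mg/kg; the change a 1.5-fold higher number from compound 1 to compound 2 (0.19 log units; within the scatter). Compound 3 `CCC(C(=O)NCc1ccccc1F)N1C(=O)CCC1=O` in this assay gives "not determined" (no result reported), so compound 3 has no number of its own to stand on, and its place in the series rests only on the values of compound 1 and compound 2. Compound 4 `CCC(C(=O)NCc1ccccc1C(F)(F)F)N1C(=O)CCC1=O` carries trifluoromethyl in place of fluoro on an aromatic carbon. Among the compounds with values here, the only measured step that bears on a substituent at this place is that from compound 1 to compound 2, which stayed within the scatter. No larger shift in this assay is therefore expected here. Compound 4 is estimated at 100 mg/kg, with a range from 50 mg/kg to 250 mg/kg.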

Compound 4, dose for half-maximal effect: > 150 mg/kg
Compound 4: a limit, no number (the forecaster's own chance of this, stated with the estimate: 20%); middle value at least 1.5-fold (0.17 log units) away from the limit.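

Compound 4 gives a limit and not a number in this assay: the limit of > 150 mg/kg in this assay, at which 1 of the 4 values shown sits. Within the data shown here, with trifluoromethyl in place of hydrogen, an at least 2.0-fold higher number from compound 1 to compound 4 (0.31 log units; beyond the scatter) is the first step at this place to lie beyond the scatter. Against chloro, an at least 1.3-fold higher number from compound 2 to compound 4 (0.12 log units; that floor lies within the scatter) has a floor that still lies within the scatter, leaving these two groups unordered.

From the compounds shown here alone, the step from fluoro to trifluoromethyl cannot be read, with no number for compound 3, and how far compound 4 lies past its limit stays open. Also open, going by these compounds, is how an amine or a carboxylic acid at this place would compare with hydrogen.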